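This account rests on a few compounds, and the source may have more. Where it says the series, first, only, none or still open, it means among the compounds named here.

Working notes on the series.

The shared core carries a benzyl group and an amino group; compounds differ at one aromatic carbon. Compound 1 `Cc1nc(N)c2nc(O)n(Cc3ccccc3)c2n1` and compound 2 `CCCc1nc(N)c2nc(O)n(Cc3ccccc3)c2n1` are measured in a functional assay on the whole organism for activation, with Mus musculus as the target; a lower number here means that less compound is needed, a higher number that more compound is needed for the effect: compound 1 gives 3 mg/kg, compound 2 gives 3 mg/kg. The change hydrogen in place of ethyl on a saturated chain carbon bound to an aromatic carbon produces no change at the digits printed from compound 2 to compound 1 (within the scatter). Compound 3 `CCCOc1nc(N)c2nc(O)n(Cc3ccccc3)c2n1` differs from compound 2 by propoxy in place of propyl on an aromatic carbon, and in this assay compound 3 gives 0.3 mg/kg, a step of a 10-fold lower number from compound 2 to compound 3 (1.00 log units; beyond the scatter); against compound 1 the step is a 10-fold lower number from compound 1 to compound 3 (1.00 log units; beyond the scatter).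

Compound 4 `COc1nc(N)c2nc(O)n(Cc3ccccc3)c2n1` is not yet measured. It differs from compound 3 by hydrogen in place of ethyl on a saturated chain carbon bound to an oxygen on an aromatic ring. This is the same kind of change as from compound 2 to compound 1, but the place is not the same: there the saturated chain carbon is bound to an aromatic carbon, here it is bound to an oxygen on an aromatic ring.

The expectation for compound 4 rests on compound 2, whose step no change at the digits printed from compound 2 to compound 1 (within the scatter) shows the shortening leaving the number unchanged, so a step of about a 1.7-fold higher number from compound 3 to compound 4 (0.22 log units; within the scatter) is expected. Compound 4 is thus estimated at 0.5 mg/kg, with a range from 0.15 mg/kg to 2 mg/kg.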

Compound 4, minimum effective dose: > 1 mg/kg
Compound 4 gave a limit, no number; the forecaster's own chance of this, stated with the estimate: 5%; middle value at least 2.0-fold (0.30 log units) away from the limit.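

In this assay compound 4 gives > 1 mg/kg, which is a limit of the assay and not a number. Replacing propoxy with methoxy gives an at least 3.3-fold higher number from compound 3 to compound 4 (0.52 log units; beyond the scatter), so the shortening that left the number unchanged on the chain bound to an aromatic carbon does not carry over unchanged to the chain bound to an oxygen on an aromatic ring: the same change on two cores in this assay, no change at the digits printed (within the scatter) from compound 2 to compound 1 and an at least 3.3-fold higher number (0.52 log units; beyond the scatter) from compound 3 to compound 4, at least 3.3-fold (0.52 log units) apart, beyond the scatter of two such steps This rests on a single pair for each place and fixes only a lower bound on the gap between the two steps, while the steps from compound 1 and from compound 2 to compound 4 cannot be read.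

With only propoxy and methoxy shown on the oxygen, the compounds leave open how the number follows chain length there. Ethoxy or butoxy would address that, and an amine such as propylamino on the same aromatic carbon would test whether the oxygen itself is needed.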